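The source may report more compounds than this note shows. Statements on the series, on what has been measured and on what is new or still open speak of the compounds shown alone.

Measured in an ADME assay on blood (Rattus norvegicus, strain Wistar Han) for protein binding, read by LC-MS, using equilibrium dialysis; a lower number here means a smaller unbound share, a higher number a larger unbound share of the compound:
compound 1 `CCNC(=O)c1cc(C(=O)NC)c(=O)n(Cc2ccccc2)c1` gives 0.38
compound 2 `CNC(=O)c1cc(C(=O)NC2CC2)cn([C@H](C)c2ccccc2)c1=O` gives 0.27
compound 3 `CNC(=O)c1cc(C(=O)NC2CC2)cn(Cc2cccc3[nH]ccc23)c1=O` gives 0.18

Compound 3 (0.18) stands within the scatter of compound 2 (0.27). Compound 1 (0.38) has a higher number than compound 3, and that gap lies beyond the scatter. Compound 4 `CNC(=O)c1cc(C(=O)NC2CC2)cn(Cc2cccc3[nH]ncc23)c1=O` has 1H-indazol-4-yl in place of 1H-indol-4-yl on a saturated chain carbon bound to an aromatic nitrogen. Going by the values given here, no measured pair differs in one place only, so the data give no direct guide to this change. A small rise in the unbound share is expected, most likely not beyond the scatter. The expected change is a 1.3-fold higher number from compound 3 to compound 4 (0.12 log units; within the scatter). The estimate for compound 4 is 0.24, with an expected range from 0.14 to 0.38.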

Compound 4, unbound fraction: 0.22
The estimate for compound 4 lay 1.1-fold (0.04 log units) above the measured number, within the range that was stated.
By their numbers in this assay, from the lowest: compounds 3, 4, 2 and 1 (each within the scatter of the next, the first and the last beyond it).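

In this assay, going by these compounds alone, the replacement of 1H-indol-4-yl by 1H-indazol-4-yl on a saturated chain carbon bound to an aromatic nitrogen gives the first single-place step, a 1.2-fold higher number from compound 3 to compound 4 (0.09 log units; within the scatter) and so no resolved change. At this position, the extra hydrogen-bond acceptor of 1H-indazol-4-yl therefore leaves the unbound share indistinguishable from that of the 1H-indol-4-yl compound.

Going by these compounds, whether an amine or a carboxylic acid at this position would move the unbound share beyond the scatter remains open. No measured property in hand bears on this step.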